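Changing the Aryl Group on the Hydrazone Carbon

A few compounds are considered here, and "the series" means these few. Any claim that something is new, unique, unknown or untested is made for them only; others in the source may bear on it.

Measured compounds:
compound 1, `CN(C)CCn1cnnc1-c1cc(Oc2ccc(NC(=O)N/N=C/c3ccc(Cl)cc3Cl)cc2F)ccn1`, 390 nM
compound 2, `CN(C)CCn1cnnc1-c1cc(Oc2ccc(NC(=O)N/N=C/c3c[nH]c4ccccc34)cc2F)ccn1`, 1300 nM
compound 3, `COc1ccc(OC)c(/C=N/NC(=O)Nc2ccc(Oc3ccnc(-c4nncn4CCN(C)C)c3)c(F)c2)c1`, 2070 nM

All three share one core and differ only in the aryl group on a carbon with a double bond to nitrogen. In a functional assay on HT-29 cells (Homo sapiens) for cytotoxicity, read by MTT assay, with a stated time of 72 h (on this read-out lower numbers stand for stronger inhibition and higher numbers for weaker inhibition), compound 2 gives the second highest of the three numbers: compound 1 sits clearly lower, a 3.3-fold higher number from compound 1 to compound 2 (0.52 log units; beyond the scatter), while compound 3 sits close by, a 1.6-fold higher number from compound 2 to compound 3 (0.20 log units; within the scatter), within the scatter. Compound 4, `CN(C)CCn1cnnc1-c1cc(Oc2ccc(NC(=O)N/N=C/c3cccc(O)c3)cc2F)ccn1`, has not yet been measured. It differs from compound 2 as follows: 3-hydroxyphenyl in place of 1H-indol-3-yl on a carbon with a double bond to nitrogen. Among the measured compounds shown here, the steps that bear on this change are the two that exchange the group at this same place: a 5.3-fold higher number from compound 1 to compound 3 (0.72 log units; beyond the scatter), beyond the scatter, and a 1.6-fold higher number from compound 2 to compound 3 (0.20 log units; within the scatter), within it. Swapping the aryl group has shifted the number modestly at most, and no measured step shows a hydroxyl at this place. For compound 4 a small step is expected, a 1.2-fold higher number from compound 2 to compound 4 (0.06 log units; within the scatter). The number for compound 4 is estimated at 1500 nM, between 600 nM and 4000 nM.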

Compound 4, half-maximal inhibitory concentration: 330 nM
For compound 4 the middle estimate is 4.5-fold (0.66 log units) above the measured one, and the stated range ends above it.
By their numbers in this assay, from the lowest: compounds 4 and 1 (each within the scatter of the next); then compounds 2 and 3 (each within the scatter of the next).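

In this assay, the 3-hydroxyphenyl group separates clearly from two of the earlier groups: a 3.9-fold lower number from compound 2 to compound 4 (0.60 log units; beyond the scatter) and a 6.3-fold lower number from compound 3 to compound 4 (0.80 log units; beyond the scatter) both lie beyond the scatter. By contrast, a 1.2-fold lower number from compound 1 to compound 4 (0.07 log units; within the scatter) stays within the scatter, so two quite different aryl groups, 3-hydroxyphenyl and 2,4-dichlorophenyl, cannot be told apart here, and a hydroxyl and two chlorines on this ring give matching results. No measurement is available to explain why these groups sort this way.

A plain phenyl or a 3-methoxyphenyl group at this place would help show whether the hydroxyl itself accounts for the step. Going by these compounds, whether an amine or a carboxylic acid on this ring would give a similarly low number also remains open.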